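Swapping amino for methyl on the shared pyrimidine-free core

This account rests on a few compounds, and the source may have more. Where it says the series, first, only, none or still open, it means among the compounds named here.

Of the compounds shown here, three have been measured in an assay on BTI-TN-5B1-4 cells for inhibition of Amine oxidase [flavin-containing] B (Homo sapiens), read by fluorescence and Amplex Red, using microsomes, with a stated time of 30 min; on this read-out higher numbers stand for weaker inhibition and lower numbers for stronger inhibition. Compound 1 `C#CCOc1ccc(-c2cc(-c3ccc(OCC#C)cc3)nc(C)n2)cc1` gives 7830 nM, compound 2 `C#CCOc1ccc(-c2cc(-c3ccc(OCC#C)c(OCC)c3)nc(-c3ccccc3)n2)cc1` gives 29000 nM, and compound 3 `C#CCOc1ccc(-c2cc(-c3ccc(OCC#C)c(OCC)c3)nc(N)n2)cc1` gives 14000 nM. On these numbers compound 3 stands second highest of the three: the gap to compound 1 lies within the usual scatter, while the gap to compound 2 is larger, shown by a 2.1-fold lower number from compound 2 to compound 3 (0.32 log units; beyond the scatter), a modest step for putting an amino group in place of phenyl.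

Compound 4 `C#CCOc1ccc(-c2cc(-c3ccc(OCC#C)c(OCC)c3)nc(C)n2)cc1` differs from compound 3 by methyl in place of amino on an aromatic carbon. Among the measured compounds shown here, no measured pair shows exactly this swap. The closest evidence is compound 1, which already carries the methyl at the same place and whose number sits close to that of compound 3, and the step from compound 2 to compound 3, which shows that changing this group moves the read-out only modestly. In this assay the step from compound 3 to compound 4 is therefore expected to be small, a 1.6-fold lower number from compound 3 to compound 4 (0.19 log units; within the scatter), and compound 4 is estimated at 9000 nM, between 4000 nM and 20000 nM.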

Compound 4, half-maximal inhibitory concentration: 11000 nM
The estimate for compound 4 lay 1.2-fold (0.09 log units) below the measured number; measured number inside the range.
By their numbers in this assay, from the lowest: compounds 1, 4 and 3 (each within the scatter of the next); then compound 2.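

In this assay, the direct swap at this carbon between two ring nitrogen atoms gives a 1.3-fold lower number from compound 3 to compound 4 (0.10 log units; within the scatter), so this pair does not separate methyl from amino, even though only amino counts hydrogen-bond donors and acceptors. Phenyl does separate from methyl, with a 2.6-fold lower number from compound 2 to compound 4 (0.42 log units; beyond the scatter), a modest step, while the ethoxy group on the shared core makes no difference that can be told from scatter, with a 1.4-fold higher number from compound 1 to compound 4 (0.15 log units; within the scatter). No measurement shown here explains any of these steps.

From the compounds shown here alone, it remains open whether a carboxylic acid, a methoxy group or a longer chain at this carbon would shift the number further than methyl or amino do. Going by these compounds, it also remains open whether a longer alkoxy chain or a fluorine in place of the ethoxy group would have any more effect than ethoxy.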